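Moving from hydroxy to carbamoyl on the side chain

A few compounds are considered here, and "the series" means these few. Any claim that something is new, unique, unknown or untested is made for them only; others in the source may bear on it.

Of the compounds shown here, three sharing one core have been measured in a functional assay on the whole organism (Tail, strain ICR) with Mus musculus as the target, in the tail flick test, with a stated time of 60 min, at a dose of 25 umol/kg by the oral route; on this read-out lower numbers stand for a weaker effect and higher numbers for a stronger effect at the one dose given. Compound 1 `O=C(O)CC[C@H](NC(=O)CN(c1nc(Cl)nc2[nH]cnc12)C1CC1)C(=O)O` gives 33.3%, compound 2 `NC(=O)CC[C@H](NC(=O)CN(c1nc(Cl)nc2[nH]cnc12)C1CC1)C(=O)O` gives 38.4%, and compound 3 `O=C(CN(c1nc(Cl)nc2[nH]cnc12)C1CC1)N[C@@H](CO)C(=O)O` gives 39.8%. Compound 3 holds the highest of the three numbers, but the steps of a number 6.5 percentage points higher from compound 1 to compound 3 (within the scatter) and a number 1.4 percentage points higher from compound 2 to compound 3 (within the scatter) both lie within the scatter, so no order among them can be claimed. Compound 4 `NC(=O)C[C@H](NC(=O)CN(c1nc(Cl)nc2[nH]cnc12)C1CC1)C(=O)O` differs from compound 3 as follows: carbamoyl in place of hydroxy on a saturated chain carbon, two bonds along the chain from an amide-type nitrogen and a carbonyl carbon. The step of a number 1.4 percentage points higher from compound 2 to compound 3 (within the scatter) concerns the same chain carbon with a closely related group and was small, as was a number 5.1 percentage points higher from compound 1 to compound 2 (within the scatter) between the two longer side chains. In this assay compound 4 is therefore expected to sit near compound 3, the step of a number 1.8 percentage points lower from compound 3 to compound 4 (within the scatter) estimated to stay within the scatter. The estimate for compound 4 is 38%, with a range from 27% to 49%.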

Compound 4, a percentage reported as activity, at one dose (the size of the read-out at that dose, not a potency): 43.1%
Compound 4: middle estimate off by 5.1 percentage points, on the low side; the measured number falls inside the stated range.
By their numbers in this assay, from the lowest: compounds 1, 2, 3 and 4 (each within the scatter of the next).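

Carbamoyl on this saturated chain carbon cannot be told apart from hydroxy in this assay (a number 3.3 percentage points higher from compound 3 to compound 4 (within the scatter)). The same holds against carbamoylmethyl (a number 4.7 percentage points higher from compound 2 to compound 4 (within the scatter)) and carboxymethyl (a number 9.8 percentage points higher from compound 1 to compound 4 (within the scatter)), so the shorter amide side chain adds a fourth group at this position with no readable difference at this one dose. Nothing at hand offers an explanation for these small steps.

Going by these compounds, whether an amine, a methyl group or a phenyl ring on this carbon would give a different number remains open. So does whether these four compounds would separate at another dose or time.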